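The source may hold more compounds than are shown below. What is called first, only, known or untested is meant among the compounds shown, and "the series" means these compounds.

Values so far in a functional assay on DU-145 cells (Homo sapiens) for inhibition, read by trypan blue exclusion, with a stated time of 96 h; on this read-out lower numbers stand for stronger inhibition of growth and higher numbers for weaker inhibition of growth:
- compound 1 `O=C(O)c1ccc(C(=O)/C(=C\c2ccc(O)c([N+](=O)[O-])c2)SCc2ccc(Br)cc2)cc1` gives 50000 nM
- compound 2 `COc1ccc(C(=O)/C(=C\c2ccc(O)c([N+](=O)[O-])c2)SCc2ccc(Br)cc2)cc1` gives 10000 nM

Compound 2 has the lower of these two numbers, so it is the better growth inhibitor of the pair. The next compound to be tested is compound 3 `O=C(/C(=C\c1ccc(O)c([N+](=O)[O-])c1)SCc1ccc(Br)cc1)C1CCNC1`. It keeps the shared core of compound 2 but carries pyrrolidin-3-yl in place of 4-methoxyphenyl on a carbonyl carbon.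

Among the measured compounds shown here, only one measured step bears on this change: a 5.0-fold lower number from compound 1 to compound 2 (0.70 log units; beyond the scatter), with methoxy in place of carboxy on an aromatic carbon. For the measured compounds named here, that modest step altered only one group on the aromatic ring, whereas compound 3 has lost the ring altogether, so the guidance is weak. A step of similar modest size is expected, towards a higher number and weaker inhibition, though the direction is uncertain.

The estimated change is a 2.5-fold higher number from compound 2 to compound 3 (0.40 log units; beyond the scatter) in this expectation.

For compound 3 the expected value is 25000 nM, with an estimated range from 6000 nM to 80000 nM as its likely span.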

Compound 3, concentration for 50% growth inhibition: > 100000 nM
Compound 3 gave a limit, no number; the forecaster's own chance of this, stated with the estimate: 15%; middle value at least 4.0-fold (0.60 log units) away from the limit.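

Replacing 4-methoxyphenyl with pyrrolidin-3-yl on the carbonyl carbon gives an at least 10-fold higher number from compound 2 to compound 3 (1.00 log units; beyond the scatter). The earlier pair differed only in a group on the aromatic ring, whereas this change replaces the whole aromatic group and shows that growth inhibition does not survive it at the concentrations reached in this assay. Against the weaker compound of that earlier pair, the same replacement gives an at least 2.0-fold higher number from compound 1 to compound 3 (0.30 log units; that floor lies within the scatter), so compound 3 is clearly separated from compound 2, while the floor of its step from compound 1 does not by itself set the two firmly apart, and both steps remain floors because the reading for compound 3 is a limit of the assay and not a number: the limit of > 100000 nM in this assay, at which 1 of the 3 values shown sits.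

The compounds shown cannot say whether the loss goes with giving up the aromatic ring or with bringing in the ring nitrogen and its hydrogen. A cyclopentyl ring, which has no nitrogen, and a pyridine ring, which keeps an aromatic ring and holds a nitrogen, would be the groups to separate these two readings at this place.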